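Methoxy in Place of Fluoro on a Rearranged Core

The compounds below may be only part of what the source reports. "The series", "measured", "known", "first", "only" and "open" are said of these compounds alone.

Measured so far:
compound 1, `Cn1cc(-c2cnc3ccc(NC(=O)c4ccc(F)cc4)nc3c2)cn1`, > 50000 nM
compound 2, `COc1ccc(C(=O)Nc2ccc3ncc(-c4cnn(C)c4)cc3n2)cc1`, 6400 nM
compound 3, `Cn1cc(-c2cnc3ccnc(NC(=O)c4ccc(F)cc4)c3c2)cn1`, > 50000 nM

Of the compounds shown here, three have been tested in a functional assay on A549 cells (Homo sapiens) for antiproliferative activity, read by MTT assay, with a stated time of 48 h; on this read-out higher numbers stand for weaker inhibition and lower numbers for stronger inhibition. In this assay compound 1 gives only a limit, > 50000 nM, not a number. Compound 2 differs from compound 1 by methoxy in place of fluoro on an aromatic carbon. Compound 2 gives a number, 6400 nM. That single change produced an at least 7.8-fold lower number from compound 1 to compound 2 (0.89 log units; beyond the scatter). Because the limit of > 50000 nM in this assay, at which 2 of the 3 values shown sit, applies to compound 1, the true size of that step can only be read as a lower bound.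

Compound 3 is built from the same atoms as compound 1, joined differently; the difference between the two cores is not broken down here. In this assay compound 3 likewise gives only a limit, > 50000 nM.

Compound 4, `COc1ccc(C(=O)Nc2nccc3ncc(-c4cnn(C)c4)cc23)cc1`, has not yet been measured. It differs from compound 3 by methoxy in place of fluoro on an aromatic carbon, the same change that separates compound 2 from compound 1, made at the same kind of place on the aromatic ring. Whether it pays off in the same way on the rearranged core cannot be read from compound 3 alone, since compound 3 gives only a limit. The expectation is that the step from compound 3 to compound 4 is an at least 3.3-fold lower number from compound 3 to compound 4 (0.52 log units; beyond the scatter), smaller and less certain than the earlier one, resting on the fact that compound 1 showed an at least 7.8-fold lower number from compound 1 to compound 2 (0.89 log units; beyond the scatter) after the same change. Compound 4 is therefore estimated at 15000 nM, with a range from 4000 nM to 60000 nM.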

Compound 4, half-maximal inhibitory concentration: > 50000 nM
Compound 4: a limit, no number (the forecaster's own chance of this, stated with the estimate: 45%); at least 3.3-fold (0.52 log units) between middle value and limit.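

In this assay compound 4 gives > 50000 nM as a limit, not a number. Among these compounds, compound 3 also gives only a limit, so no step from compound 3 to compound 4 can be read, because both compounds sit at that limit: the limit of > 50000 nM in this assay, at which 3 of the 4 values shown sit.

The compounds shown leave open whether methoxy in place of fluoro changes the number at all on the core shared by compound 3 and compound 4.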